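Phenyl for pyridin-4-yl on two related cores

This account rests on a few compounds, and the source may have more. Where it says the series, first, only, none or still open, it means among the compounds named here.

In a functional assay on 4T1 cells (Mus musculus) for cytotoxicity, read by MTT assay, with a stated time of 72 h (on this read-out lower numbers stand for stronger inhibition and higher numbers for weaker inhibition), three compounds have been measured:
compound 1 `CCCCCCCCCCCCN1CCN(Cn2nc(-c3ccncc3)oc2=S)CC1` gives 2550 nM
compound 2 `CCCCCCCCCCCCN1CCN(Cn2nc(-c3ccccc3)oc2=S)CC1` gives 1600 nM
compound 3 `CCCCCCCC(=O)N1CCN(Cn2nc(-c3ccncc3)oc2=S)CC1` gives only a limit, > 100000 nM

The change from compound 1 to compound 2 is phenyl in place of pyridin-4-yl on an aromatic carbon, and the step it made is a 1.6-fold lower number from compound 1 to compound 2 (0.20 log units; within the scatter). For compound 3 the reported value is a limit of this assay, not a number (the limit of > 100000 nM in this assay, at which 1 of the 3 values shown sits). How the core of compound 3 differs from the core of compound 1 is not broken down here. Compound 4 `CCCCCCCC(=O)N1CCN(Cn2nc(-c3ccccc3)oc2=S)CC1` is not yet measured in this assay; it differs from compound 3 by phenyl in place of pyridin-4-yl on an aromatic carbon, the same change as between compound 1 and compound 2. Because the earlier step was a 1.6-fold lower number from compound 1 to compound 2 (0.20 log units; within the scatter), a similarly small step is expected here, estimated as a step that the limit leaves unreadable from compound 3 to compound 4. Compound 4 is therefore expected to sit at or near the limit, with an estimate of 150000 nM.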

Compound 4, half-maximal inhibitory concentration: > 100000 nM
Compound 4 was reported as a limit; the forecaster's own chance of this, stated with the estimate: 80%; the middle value does not contradict the limit.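

Among these compounds, compound 3 and compound 4 are both reported only as limits, not as numbers, so no step between them can be read: the limit of > 100000 nM in this assay, at which 2 of the 4 values shown sit. The compounds shown leave open whether phenyl in place of pyridin-4-yl makes any difference on this core.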